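Adding a Methoxy to the Carbonyl Aryl of Compound 3

A few compounds are considered here, and "the series" means these few. Any claim that something is new, unique, unknown or untested is made for them only; others in the source may bear on it.

Among the measured compounds shown here, compound 3 `COc1ccc(C(=O)/C=C/c2cc(-c3cc(OC)c(OC)c(OC)c3)n[nH]2)cc1OC` gives 91% in a functional assay on ACHN cells (Homo sapiens) for cytotoxicity, read by sulforhodamine B assay, with a stated time of 48 h, tested at 1 uM (a lower number here means a stronger effect, a higher number a weaker effect of the compound at the concentration tested), the second highest of the three numbers measured so far. Compound 2 `COc1cc(-c2cc(/C=C/C(=O)c3ccc(Cl)c(Cl)c3)[nH]n2)cc(OC)c1OC` gives 101%, and the step of a number 10 percentage points lower from compound 2 to compound 3 (within the scatter) lies within the scatter. Compound 1 `COc1cc(-c2cc(/C=C/C(=O)c3ccc(N)cc3)[nH]n2)cc(OC)c1OC` gives 79%; the steps of a number 22 percentage points higher from compound 1 to compound 2 (beyond the scatter) and a number 12 percentage points higher from compound 1 to compound 3 (beyond the scatter) came from exchanging the whole group on the carbonyl carbon. Compound 4 `COc1cc(C(=O)/C=C/c2cc(-c3cc(OC)c(OC)c(OC)c3)n[nH]2)cc(OC)c1OC` differs from compound 3 by methoxy in place of hydrogen on an aromatic carbon. For the measured compounds named here, no measured step adds or removes a methoxy on this ring, so the three steps bear only loosely on it. The exchanges of the whole group moved the number modestly, and a smaller addition is expected to move it less. Compound 4 is therefore estimated at 90%, with a range of 72% to 105%, a step of a number 1 percentage points lower from compound 3 to compound 4 (within the scatter) that is expected to stay within the scatter.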

Compound 4, a percentage reported as activity, at one concentration (the size of the read-out at that concentration, not a potency): 89%
Beside the measured number, compound 4's estimate is 1 percentage points above it; the range from low to high includes it.
By their numbers in this assay, from the lowest: compounds 1, 4, 3 and 2 (each within the scatter of the next, the first and the last beyond it).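

Adding a methoxy to the carbonyl aryl, ortho to a methoxy group, gives a number 2 percentage points lower from compound 3 to compound 4 (within the scatter) in this assay. Unlike the exchanges of the whole group on the carbonyl carbon, this smaller change on the same ring leaves no readable difference, so this position tolerates the methoxy without a shift in the number. Nothing available explains this result. The compounds shown leave open whether a hydroxy group or a carboxylic acid at this position would move the number beyond the scatter.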